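The source may hold more compounds than are shown below. What is called first, only, known or untested is meant among the compounds shown, and "the series" means these compounds.

Compound 1 `Cc1cc(Nc2cc(-c3ccccc3)[nH]n2)n2nc(SCc3ccc(Cl)cc3)nc2n1`: 8260 nM
Compound 2 `C#CCSc1nc2nc(C)cc(Nc3cc(-c4ccccc4)[nH]n3)n2n1`: 21800 nM

For the measured compounds named here, in a functional assay on MCF7 cells (Homo sapiens) for inhibition, read by MTT assay, with a stated time of 72 h (on this read-out lower numbers stand for stronger inhibition and higher numbers for weaker inhibition), compound 2, at 21800 nM, has the higher of the two numbers so far, which makes it the weaker inhibitor of the pair. Compound 3 `C=CCSc1nc2nc(C)cc(Nc3cc(-c4ccccc4)[nH]n3)n2n1` keeps the shared core and alters one small group: vinyl in place of ethynyl on a saturated chain carbon bound to a sulfur. Put simply, this is vinyl in place of ethynyl on a saturated chain carbon bound to a sulfur, so propargylsulfanyl becomes allylsulfanyl.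

Going by the values given here, only one measured step bears on this, and it is modest: a 2.6-fold higher number from compound 1 to compound 2 (0.42 log units; beyond the scatter). There, ethynyl replaced 4-chlorophenyl at that same place. Exchanging ethynyl for vinyl is a much smaller structural change, so no step beyond the usual scatter is expected in this assay, in either direction. Among the compounds with values here, no measured compound yet carries vinyl, so this remains an inference from a single step. The expected change is a 1.1-fold lower number from compound 2 to compound 3 (0.06 log units; within the scatter), and it is only an estimate. For compound 3, the estimated value is 19000 nM, with an expected range from 9500 nM to 38000 nM.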

Compound 3, half-maximal inhibitory concentration: > 50000 nM
Compound 3: a limit, no number (the forecaster's own chance of this, stated with the estimate: 5%); middle value at least 2.6-fold (0.42 log units) from the limit.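

In this assay, compound 3 gives > 50000 nM, which is a limit of the assay and not a number. Even so, the change of ethynyl to vinyl on a saturated chain carbon bound to a sulfur can be read as a minimum, an at least 2.2-fold higher number from compound 2 to compound 3 (0.36 log units; beyond the scatter), so this position responds to exchanging a triple bond for a double bond, even though the heavy-atom count stays the same. Set against the 4-chlorophenyl group at the same place, vinyl gives an at least 6.0-fold higher number from compound 1 to compound 3 (0.78 log units; beyond the scatter), and with all three compounds now in hand the numbers rise in the order 4-chlorophenyl, ethynyl, vinyl, an order that holds only for these three groups.

From the compounds shown here alone, how far compound 3 lies past its limit remains unknown, so the true size of both steps stays open. Also open, going by these compounds, is how a plain propyl chain, a longer chain, an amine or a carboxylic acid at this place would read, and whether any of them would give a lower number than compound 1 at 8260 nM.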